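Trifluoromethyl on the Benzyl Arm: Expected Potency of Compound 4

This account rests on a few compounds, and the source may have more. Where it says the series, first, only, none or still open, it means among the compounds named here.

Three compounds share one core and differ only in the group carried on the triazole nitrogen. Compound 1 `CC(C)n1ncc2c(C(=O)NCc3cn(-c4ccccc4)nn3)cccc21` carries a phenyl there, compound 2 `CC(C)n1ncc2c(C(=O)NCc3cn(-c4ccc(C(F)(F)F)cc4)nn3)cccc21` a 4-(trifluoromethyl)phenyl, and compound 3 `CC(C)n1ncc2c(C(=O)NCc3cn(Cc4ccccc4)nn3)cccc21` a benzyl. All three were tested in a functional assay on MGC-803 cells (Homo sapiens) for inhibition, read by MTT assay, with a stated time of 72 h; a lower number here means a stronger inhibitor, a higher number a weaker inhibitor.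

In this assay compound 1 stops at the limit of the assay, > 40000 nM, and yields no number. Compound 2 likewise stops at the assay limit of > 40000 nM. Among the measured compounds shown here, compound 3 gives 14300 nM, the only true number in the set. The change benzyl in place of phenyl on an aromatic nitrogen therefore produces an at least 2.7-fold lower number from compound 1 to compound 3 (0.44 log units; beyond the scatter), and the related change from compound 2 produces an at least 2.7-fold lower number from compound 2 to compound 3 (0.44 log units; beyond the scatter).

The change trifluoromethyl in place of hydrogen on an aromatic carbon produces a step that the two limits leave unreadable from compound 1 to compound 2 because both values sit at the limit of > 40000 nM in this assay, at which 2 of the 3 values shown sit.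

Compound 4 `CC(C)n1ncc2c(C(=O)NCc3cn(Cc4ccc(C(F)(F)F)cc4)nn3)cccc21` has not yet been measured. It arises from compound 3 by trifluoromethyl in place of hydrogen on an aromatic carbon, the same change as that from compound 1 to compound 2, made at the same kind of place on the ring. For the measured compounds named here, since the one measured example of this change cannot be read, the expectation for compound 4 rests on compound 3 alone, whose value is 14300 nM, and it carries a wide range. Compound 4 is thus expected to give about 14000 nM, with an estimated spread from 4000 nM to 45000 nM. The step this estimate implies is a 1.0-fold lower number from compound 3 to compound 4 (0.01 log units; within the scatter).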

Compound 4, half-maximal inhibitory concentration: > 40000 nM
Compound 4 was reported as a limit; the forecaster's own chance of this, stated with the estimate: 30%; at least 2.8-fold (0.45 log units) between middle value and limit.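

On the benzyl arm, trifluoromethyl in place of hydrogen gives an at least 2.7-fold higher number from compound 3 to compound 4 (0.44 log units; beyond the scatter) in this assay, and a higher number here means a weaker inhibitor, so this one readable case is a clear loss of activity whose full size stays hidden behind a limit. The same change on the phenyl arm, from compound 1 to compound 2, cannot be read, so it neither supports nor contradicts this loss, and nothing shows that the change has the same effect on both arms. A transfer from one arm to the other therefore remains untested, and a single readable step is no rule for the series, as most of the set ends at one ceiling: the limit of > 40000 nM in this assay, at which 3 of the 4 values shown sit.

What the compounds shown leave open is whether any other group in the place taken by trifluoromethyl, such as a methoxy group, an amine or a carboxylic acid, would keep or improve on the activity of compound 3, which gives 14300 nM. They also leave open what a longer chain, such as a two-carbon link in place of the single carbon of the benzyl arm, would do in this assay.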